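Methylation of the sulfanyl group in two methylene-sugar nucleosides

The source may hold more compounds than are shown below. What is called first, only, known or untested is meant among the compounds shown, and "the series" means these compounds.

Measured compounds:
- compound 1, `C=C1[C@@H](O)[C@H](n2cnc3c(S)nc(N)nc32)O[C@@H]1CO`: 12000 nM
- compound 2, `C=C1[C@@H](O)[C@H](n2cnc3c(SC)nc(N)nc32)O[C@@H]1CO`: > 500000 nM
- compound 3, `C=C1[C@H](n2cnc3c(S)nc(N)nc32)O[C@H](CO)[C@H]1O`: 480 nM

Compound 1 `C=C1[C@@H](O)[C@H](n2cnc3c(S)nc(N)nc32)O[C@@H]1CO` carries a sulfanyl group on its core. In a functional assay on MT4 cells (Homo sapiens) for inhibition (a lower number here means a stronger inhibitor, a higher number a weaker inhibitor), compound 1 gives 12000 nM. Compound 2 `C=C1[C@@H](O)[C@H](n2cnc3c(SC)nc(N)nc32)O[C@@H]1CO` differs from it by methyl in place of hydrogen on a sulfur. For compound 2 the reading in this assay is a limit of the assay and not a number, > 500000 nM. The step of an at least 41-fold higher number from compound 1 to compound 2 (1.61 log units; beyond the scatter) therefore rests on a limit, the one noted as the limit of > 500000 nM in this assay, at which 1 of the 3 values shown sits, and its true size may be larger.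

Compound 3 `C=C1[C@H](n2cnc3c(S)nc(N)nc32)O[C@H](CO)[C@H]1O` has the same atoms as compound 1, joined differently; the difference between the two cores is not broken down here. In this assay compound 3 gives 480 nM, the lowest number among the measured compounds.

Compound 4 `C=C1[C@H](n2cnc3c(SC)nc(N)nc32)O[C@H](CO)[C@H]1O` is not yet measured. It stands to compound 3 as compound 2 stands to compound 1: methyl in place of hydrogen on a sulfur. The place is described identically in both pairs, so the same change is made on a different core. On the core of compound 1 this change gave an at least 41-fold higher number from compound 1 to compound 2 (1.61 log units; beyond the scatter). Compound 4 is expected to show a step of similar size, an 83-fold higher number from compound 3 to compound 4 (1.92 log units; beyond the scatter), because the measured change an at least 41-fold higher number from compound 1 to compound 2 (1.61 log units; beyond the scatter) was large. The estimate for compound 4 in this assay is 40000 nM, within 5000 nM to 500000 nM, with a real chance that only a limit is reported.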

Compound 4, half-maximal inhibitory concentration: > 500000 nM
Compound 4 ended at the assay's limit; the forecaster's own chance of this, stated with the estimate: 35%; middle value at least 12-fold (1.09 log units) from the limit.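

Carried to the second core, the change from sulfanyl to methylsulfanyl gives in this assay an at least 1000-fold higher number from compound 3 to compound 4 (3.01 log units; beyond the scatter), so the direction seen on the first core is seen again, and on both cores shown the free sulfanyl compound is the one that gives a measured number. Compound 2 and compound 4 both end at a limit of the assay and not at a number: the limit of > 500000 nM in this assay, at which 2 of the 4 values shown sit. The direction therefore carries across these two cores, but the size of the step does not become comparable, and nothing here shows that one core tolerates the methyl better than the other: the same change on two cores in this assay, an at least 41-fold higher number (1.61 log units; beyond the scatter) from compound 1 to compound 2 and an at least 1000-fold higher number (3.01 log units; beyond the scatter) from compound 3 to compound 4; the limit leaves it open whether they differ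

Only hydrogen and methyl on the sulfur are shown, which leaves open whether a longer chain such as ethyl, or a benzyl group, on that sulfur would also end at the limit on either core. Also open, from the compounds shown here alone, is whether an amine or a hydroxyl group in place of the sulfanyl group would keep a reading close to that of compound 3, 480 nM, in this assay.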